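Carbamate tail on a furanone core: isopropyl to cyclohexyl

This account rests on a few compounds, and the source may have more. Where it says the series, first, only, none or still open, it means among the compounds named here.

Compound 1 `C/C(=C\COC(=O)NC(C)C)C1=CC(=O)C(C)(C)O1`: 6.6 ug/mL
Compound 2 `C/C(=C\C=C/C1CCCCC1)C1=CC(=O)C(C)(C)O1`: 7.1 ug/mL
Compound 3 `C/C(=C\C=C\c1ccccc1)C1=CC(=O)C(C)(C)O1`: 14 ug/mL

In a functional assay on MOLT-4F cells (Homo sapiens) for inhibition (on this read-out higher numbers stand for weaker inhibition and lower numbers for stronger inhibition), compound 1 gives the lowest of the three numbers, but compound 2 sits within the scatter of it, so the two cannot be ranked; only compound 3 lies beyond the scatter, above compound 1.

Compound 4 `C/C(=C\COC(=O)NC1CCCCC1)C1=CC(=O)C(C)(C)O1` differs from compound 1 in one place: cyclohexyl in place of isopropyl on an amide-type nitrogen. Among the measured compounds shown here, no measured pair shows this change directly, so the expectation rests on the numbers above. In this assay a small step is expected, in either direction or none beyond the scatter. The value of compound 4 is estimated at 6 ug/mL, between 2.5 ug/mL and 15 ug/mL, a step of a 1.1-fold lower number from compound 1 to compound 4 (0.04 log units; within the scatter).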

Compound 4, half-maximal inhibitory concentration: 3.4 ug/mL
For compound 4 the middle estimate is 1.8-fold (0.25 log units) above the measured one; measured number inside the range.
By their numbers in this assay, from the lowest: compounds 4, 1, 2 and 3 (each within the scatter of the next, the first and the last beyond it).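

Going from isopropyl to cyclohexyl on the amide-type nitrogen in this assay gives a small step (a 1.9-fold lower number from compound 1 to compound 4 (0.29 log units; within the scatter)), so compound 1 and compound 4 cannot be ranked. Among the compounds shown here, this is the first direct comparison at this position, and it shows that the larger, ring-bearing group is accepted there without a change beyond the usual scatter. No measurement shown here accounts for this result. Going by these compounds, whether a methyl group, a benzyl group, a longer chain or a carboxylic acid on that nitrogen would shift the number beyond the scatter remains open.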